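The compounds below may be only part of what the source reports. "The series", "measured", "known", "first", "only" and "open" are said of these compounds alone.

Working notes on the series. In a functional assay on MCF7 cells (Homo sapiens) for cytotoxicity, read by MTT assay, with a stated time of 72 h (a lower number here means a stronger inhibitor, a higher number a weaker inhibitor), compound 1 (`COc1cccc(/C=C2\CCC/C(=C\c3cccc(OC)c3OC)C2=O)c1`) gives 5900 nM and compound 2 (`COc1ccc(/C=C2\CCC/C(=C\c3cccc(OC)c3OC)C2=O)cc1OC`) gives 6500 nM, while compound 3 (`COc1cc(/C=C2\CCC/C(=C\c3cccc(OC)c3OC)C2=O)cc(OC)c1`) gives 1700 nM as the lowest number of the three. Compound 4 (`COc1cccc(/C=C2\CCC/C(=C\c3cc(OC)c(OC)c(OC)c3)C2=O)c1OC`) is still unmeasured and differs from compound 3 by one change (methoxy in place of hydrogen on an aromatic carbon). The new methoxy stands in place of hydrogen on an aromatic carbon, ortho to two methoxy groups and para to a large group. Two measured steps also add a methoxy in place of hydrogen on an aromatic carbon. The closer precedent shows a 1.1-fold higher number from compound 1 to compound 2 (0.04 log units; within the scatter) and puts the methoxy para to a large group, as in compound 4. The other shows a 3.5-fold lower number from compound 1 to compound 3 (0.54 log units; beyond the scatter) but its added methoxy is not para to a large group, so it carries less weight here. No step beyond the scatter is therefore expected in this assay, with at most a slight drift toward a higher number. The estimated step is a 1.4-fold higher number from compound 3 to compound 4 (0.13 log units; within the scatter) on that reading. The estimate for compound 4 is 2300 nM with an expected range from 900 nM to 6500 nM at its two ends.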

Compound 4, half-maximal inhibitory concentration: 1400 nM
The estimate for compound 4 lay 1.6-fold (0.22 log units) above the measured number, and the stated range covers the measured number.
By their numbers in this assay, from the lowest: compounds 4 and 3 (each within the scatter of the next); then compounds 1 and 2 (each within the scatter of the next).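

In this assay, the methoxy ortho to two methoxy groups and para to a large group now has a second reading on another core, a 1.2-fold lower number from compound 3 to compound 4 (0.08 log units; within the scatter), and the two readings agree: the same change on two cores in this assay, a 1.1-fold higher number (0.04 log units; within the scatter) from compound 1 to compound 2 and a 1.2-fold lower number (0.08 log units; within the scatter) from compound 3 to compound 4, 1.3-fold (0.13 log units) apart, within the scatter of two such steps. The methoxy added at the other place on that ring, a 4.6-fold lower number from compound 2 to compound 4 (0.67 log units; beyond the scatter), likewise repeats its earlier step on a second core: the same change on two cores in this assay, a 3.5-fold lower number (0.54 log units; beyond the scatter) from compound 1 to compound 3 and a 4.6-fold lower number (0.67 log units; beyond the scatter) from compound 2 to compound 4, 1.3-fold (0.13 log units) apart, within the scatter of two such steps. Across these four compounds, the size of the step goes with where the methoxy is placed and holds on both cores, with no compound against it.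

On these data alone, only hydrogen and methoxy appear at this position, so what a hydroxyl, an amine or a longer ethoxy chain would do there stays open. As far as these compounds go, whether these steps hold outside this assay also stays open.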